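A few compounds are considered here, and "the series" means these few. Any claim that something is new, unique, unknown or untested is made for them only; others in the source may bear on it.

Among the measured compounds shown here, in a functional assay on HCT-116 cells (Homo sapiens) for antiproliferative activity, read by MTT assay, with a stated time of 72 h (on this read-out lower numbers stand for stronger inhibition and higher numbers for weaker inhibition), compound 2 `O=C(O)CCCCCCCOc1ccc2cc1COC/C=C/COCc1cccc(c1)-c1ccnc(n1)N2` gives 8040 nM, the higher of the two numbers measured so far; compound 1 `O=C(CCCCCOc1ccc2cc1COC/C=C/COCc1cccc(c1)-c1ccnc(n1)N2)NO` gives 2560 nM. For the measured compounds named here, the only measured step, a 3.1-fold higher number from compound 1 to compound 2 (0.50 log units; beyond the scatter), put a 2-carboxyethyl group in place of a hydroxycarbamoyl and raised the number by a modest amount. Compound 3 `O=C(NO)c1ccc(NCCOc2ccc3cc2COC/C=C/COCc2cccc(c2)-c2ccnc(n2)N3)cc1` differs from compound 2 as follows: (4-(hydroxycarbamoyl)phenyl)amino in place of 5-carboxypentyl on a saturated chain carbon, two bonds along the chain from an oxygen on an aromatic ring. This change brings a hydroxycarbamoyl back, so for compound 3 a lower number is expected, roughly undoing the earlier step, as a 5.4-fold lower number from compound 2 to compound 3 (0.73 log units; beyond the scatter). Compound 3 is therefore estimated at 1500 nM, within a range from 400 nM to 6000 nM.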

Compound 3, half-maximal inhibitory concentration: 3200 nM
Beside the measured number, compound 3's estimate is 2.1-fold (0.33 log units) below it; low and high end bracket the measured number.
By their numbers in this assay, from the lowest: compounds 1 and 3 (each within the scatter of the next); then compound 2.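

In this assay, a hydroxycarbamoyl carried on (4-(hydroxycarbamoyl)phenyl)amino, a group with an aromatic ring, still comes with a 2.5-fold lower number from compound 2 to compound 3 (0.40 log units; beyond the scatter) in place of the 5-carboxypentyl group. Set against the 3-(hydroxycarbamoyl)propyl group, the same ring-bearing group gives a 1.3-fold higher number from compound 1 to compound 3 (0.10 log units; within the scatter), so at this position these two hydroxycarbamoyl-bearing groups cannot be told apart. Nothing measured here explains these numbers. Still open, going by these compounds, is whether the hydroxycarbamoyl matters on the ring-bearing group, which a carboxylic acid in its place would test. A longer chain between the ring and the oxygen also remains untested among the compounds shown.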